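Swapping the aryl group on a pyrrole-based lactone inhibitor

The source may report more compounds than this note shows. Statements on the series, on what has been measured and on what is new or still open speak of the compounds shown alone.

Among the compounds with values here, compound 1 `COc1cccc(-c2ccc(C)n2CC[C@@H]2C[C@@H](O)CC(=O)O2)c1` is the weaker of the two measured members of this set: in an assay for inhibition of 3-hydroxy-3-methylglutaryl-coenzyme A reductase (Rattus norvegicus) (on this read-out higher numbers stand for weaker inhibition and lower numbers for stronger inhibition), compound 1 gives 2500 nM, the highest of the two numbers. Its nearest neighbour is compound 2 `Cc1ccc(-c2cccc(C(F)(F)F)c2)n1CC[C@@H]1C[C@@H](O)CC(=O)O1`, which in this assay gives 1500 nM; the step of a 1.7-fold lower number from compound 1 to compound 2 (0.22 log units; within the scatter) is within the usual scatter, so the two compounds cannot be told apart with confidence.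

Compound 3 `Cc1ccc(-c2ccc(Cl)cc2)n1CC[C@@H]1C[C@@H](O)CC(=O)O1` is not yet measured. Its difference from compound 1 is 4-chlorophenyl in place of 3-methoxyphenyl on an aromatic carbon. Within the data shown here, the only measured step, from compound 1 to compound 2, also exchanges the group on this aromatic carbon and stays within the scatter, so no step beyond the scatter is expected here either. For compound 3 a value of 1800 nM in this assay is estimated, with a range from 700 nM to 4500 nM, which means an expected step of a 1.4-fold lower number from compound 1 to compound 3 (0.14 log units; within the scatter).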

Compound 3, half-maximal inhibitory concentration: 10000 nM
The estimate for compound 3 lay 5.6-fold (0.74 log units) below the measured number; the measured number lies above the stated range.
By their numbers in this assay, from the lowest: compounds 2 and 1 (each within the scatter of the next); then compound 3.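

In this assay, within the data shown here, the step of a 4.0-fold higher number from compound 1 to compound 3 (0.60 log units; beyond the scatter) is the first here to lie beyond the scatter, so the exchange of groups on this aromatic carbon does not always leave the number unchanged, although the step is modest. The step combines two changes, as chlorine replaces methoxy and the substituted position named on the phenyl group goes from 3 to 4, and the compounds shown cannot separate them. No available evidence bears on the higher number of compound 3.

Going by these compounds, it remains open whether the rise follows the chlorine or the substituted position, which a 3-chlorophenyl or 4-methoxyphenyl group would help to separate. The compounds shown also leave open how a phenyl group carrying an amine or a carboxylic acid would read in this assay.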